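Back to a pyrazole: clearance expected to fall

This account rests on a few compounds, and the source may have more. Where it says the series, first, only, none or still open, it means among the compounds named here.

compound 1 `CCCC(Oc1ccc(-n2cc(F)cn2)cc1)c1ccc(C(=O)NCCC(=O)O)cc1`: 12 mL/min/kg
compound 2 `CCCC(Oc1ccc(-n2cc3ccccc3n2)cc1)c1ccc(C(=O)NCCC(=O)O)cc1`: 44 mL/min/kg

For the measured compounds named here, in an ADME assay on microsomes from liver (Homo sapiens) for metabolic stability (a lower number here means slower removal, a higher number faster removal of the compound), compound 2 stands highest of the two numbers measured, with compound 1 as its only neighbour. Compound 3 `CCCC(Oc1ccc(-n2cc(OC)cn2)cc1)c1ccc(C(=O)NCCC(=O)O)cc1` differs from compound 2 by 4-methoxy-1H-pyrazol-1-yl in place of 2H-indazol-2-yl on an aromatic carbon. Going by the values given here, the one measured step that bears on this change is a 3.7-fold higher number from compound 1 to compound 2 (0.56 log units; beyond the scatter), which ran in the opposite direction, from a pyrazole to the indazole. A return to a pyrazole is therefore expected to bring a step down of roughly that size, a 2.8-fold lower number from compound 2 to compound 3 (0.44 log units; beyond the scatter). Compound 3 is estimated at 16 mL/min/kg, within a range of 8 mL/min/kg to 34 mL/min/kg.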

Compound 3, clearance: < 8 mL/min/kg
Compound 3 ended at the assay's limit; the forecaster's own chance of this, stated with the estimate: 5%; at least 2.0-fold (0.30 log units) between middle value and limit.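

In this assay compound 3 reads < 8 mL/min/kg, which is a limit of the assay and not a number: the limit of < 8 mL/min/kg in this assay, at which 1 of the 3 values shown sits.

Replacing the indazole gives an at least 5.5-fold lower number from compound 2 to compound 3 (0.74 log units; beyond the scatter), so a second substituted pyrazole, after the fluoro one in compound 1, also stands clear of the indazole at this position. Exchanging the pyrazole's substituent gives an at least 1.5-fold lower number from compound 1 to compound 3 (0.17 log units; that floor lies within the scatter), so methoxy and fluoro cannot be ordered here.

As far as these compounds go, how much slower compound 3 is cleared than the limit can show remains open. So does the effect of a nitrile or an amine in place of the methoxy on this pyrazole.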